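The compounds below may be only part of what the source reports. "The series", "measured", "known", "first", "only" and "open" are said of these compounds alone.

Of the compounds shown here, two from this series have been measured in an ADME assay on NHBE cells (Homo sapiens) for antiproliferative activity, read by MTT assay, with a stated time of 48 h; a lower number here means a stronger inhibitor, a higher number a weaker inhibitor. Compound 1 has the structure `C=CC(=O)Nc1cccc(Nc2nc(Nc3ccc(OCCn4ccnc4)cc3)ncc2Cl)c1`, and in this assay compound 1 gives 39200 nM. Compound 2 has the structure `C=CC(=O)Nc1cccc(Nc2nc(Nc3ccc(Cn4ccnc4)cc3OC)ncc2Cl)c1`. For compound 2 this assay reports only a limit, > 40000 nM, and not a number. Compound 2 thus stands at the limit of > 40000 nM in this assay, at which 1 of the 2 values shown sits. Compound 3, with the structure `C=CC(=O)Nc1cccc(Nc2nc(Nc3ccc(Cn4ccnc4)cc3)ncc2Cl)c1`, has not yet been measured in this assay. It differs from compound 2 by a single change: hydrogen in place of methoxy on an aromatic carbon. Among the compounds with values here, no measured pair in this set differs in only one place, so there is no directly comparable step to draw on. Because compound 1 already gives 39200 nM, the change is expected to leave compound 3 similarly weak, with no step beyond the usual scatter. The expected step from compound 2 to compound 3 is a number no higher from compound 2 to compound 3 (the limit leaves the size open). Compound 3 is therefore estimated at 40000 nM, within the range 15000 nM to 100000 nM.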

Compound 3, half-maximal inhibitory concentration: > 40000 nM
Compound 3: only a limit was reported; the forecaster's own chance of this, stated with the estimate: 60%; the middle value sits exactly at the limit.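

In this assay compound 3 gives > 40000 nM, which is a limit of the assay and not a number. Taking the methoxy away from this aromatic carbon therefore brings no readable number into view, the step between the two limits cannot be read, and the series now gathers at the same limit with or without that group: the limit of > 40000 nM in this assay, at which 2 of the 3 values shown sit. Putting (1H-imidazol-1-yl)methyl in place of 2-(1H-imidazol-1-yl)ethoxy gives an at least 1.0-fold higher number from compound 1 to compound 3 (0.00 log units; that floor lies within the scatter), so this second change also shows no difference that can be told apart from ordinary repeat variation.

As far as these compounds go, how far compound 2 and compound 3 lie past the limit remains unknown, and so does whether the methoxy has any effect at all on the read-out. Also open, from the compounds shown here alone, is whether an amine on this aromatic carbon, or a carboxylic acid in place of the (1H-imidazol-1-yl)methyl group, would give a readable number in this assay.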